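The source may hold more compounds than are shown below. What is called first, only, known or untested is meant among the compounds shown, and "the series" means these compounds.

Measured so far:
- compound 1 `Cc1cc(C)cc(Cc2nc(SCc3ccc([N+](=O)[O-])cc3)[nH]c(=O)c2C)c1`: > 316000 nM
- compound 2 `CCc1c(Cc2cccc(Br)c2)nc(SCc2ccc([N+](=O)[O-])cc2)[nH]c1=O`: 187000 nM
- compound 3 `CCc1c(Cc2cc(C)cc(C)c2)nc(SCc2ccc(OC)cc2)[nH]c1=O`: > 317000 nM

In an ADME assay on MT4 cells (Homo sapiens) for cytotoxicity, read by MTT assay (a higher number here means that more compound is tolerated, a lower number that less compound is tolerated), compound 3 gives no number but only a limit, namely (the limit of > 317000 nM in this assay, at which 1 of the 3 values shown sits). Compound 1 likewise sits at a limit, (the limit of > 316000 nM in this assay, at which 1 of the 3 values shown sits). Only compound 2 gives a real number in this assay, 187000 nM. So compound 3 is among the best tolerated of the three, as far as the limits allow one to say.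

Compound 4 `CCc1c(Cc2cc(C)cc(C)c2)nc(SCc2ccc([N+](=O)[O-])cc2)[nH]c1=O` has not been measured yet. It differs from compound 3 in one place: nitro in place of methoxy on an aromatic carbon. For the measured compounds named here, no directly comparable pair among the measured compounds shows what this exchange does. Compound 1 and compound 2 already carry the nitro group, and compound 1 reaches the limit while compound 2 stays at a finite number. On this basis the step from compound 3 to compound 4 in this assay is expected to be small, if anything a slight fall, and not beyond the usual scatter, with an at least 1.2-fold lower number from compound 3 to compound 4 (0.10 log units; that floor lies within the scatter) as the expected change. Compound 4 is therefore estimated at 250000 nM, with a range from 120000 nM to 400000 nM.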

Compound 4, half-maximal cytotoxic concentration: > 305000 nM
Compound 4 gave a limit, no number; the forecaster's own chance of this, stated with the estimate: 50%; middle value at least 1.2-fold (0.08 log units) away from the limit.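

In this assay compound 4 gives a limit and not a number: the limit of > 305000 nM in this assay, at which 1 of the 4 values shown sits. Carrying the 4-nitrophenyl group therefore does not by itself bring a finite number, and the steps that link compound 4 to compound 3 and to compound 1 cannot be read, as each joins two limits. For the compounds shown here, the one readable step is an at least 1.6-fold higher number from compound 2 to compound 4 (0.21 log units; that floor lies within the scatter), with 3,5-dimethylphenyl in place of 3-bromophenyl, so it does not yet show a true difference between these two groups.

Going by these compounds, the size of any effect of exchanging methoxy for nitro remains unknown, as neither compound gives a number. On these data alone, it is also open whether an amine or a carboxylic acid at this place on the ring would give a finite number in this assay.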